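Adding a chloro group: an estimate for compound 3

The source may report more compounds than this note shows. Statements on the series, on what has been measured and on what is new or still open speak of the compounds shown alone.

Compound 1 `Cn1nnnc1SCC(=O)N/N=C/c1ccccc1Cl` — in an ADME assay on NIH3T3 cells (Mus musculus) for cytotoxicity, read by XTT assay, with a stated time of 24 h (on this read-out higher numbers stand for weaker inhibition and lower numbers for stronger inhibition), compound 1 gives > 10000000 nM, which is a limit of the assay and not a number.
Compound 2 `Cn1nnnc1SCC(=O)N/N=C/c1ccccc1O` — in this assay compound 2 gives > 10000000 nM, again only a limit.

Compound 1 therefore stands at the limit and nowhere more precisely, as both values shown sit there (the limit of > 10000000 nM in this assay, at which 2 of the 2 values shown sit). Compound 3 `Cn1nnnc1SCC(=O)N/N=C/c1cccc(Cl)c1Cl` differs from compound 1 by chloro in place of hydrogen on an aromatic carbon. Among the measured compounds shown here, the one measured step, a step that the two limits leave unreadable from compound 1 to compound 2, bears on this change but cannot be read, since both of its ends are limits. In this assay no readable step is expected, a step that the limit leaves unreadable from compound 1 to compound 3. Compound 3 is therefore expected to give 20000000 nM, within 5000000 nM to 100000000 nM, most likely reported again only as a limit.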

Compound 3, half-maximal inhibitory concentration: 520000 nM
Beside the measured number, compound 3's estimate is 38-fold (1.59 log units) above it, outside the stated range (below it).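

Chloro in place of hydrogen at this position, ortho to a chloro group, brings an at least 19-fold lower number from compound 1 to compound 3 (1.28 log units; beyond the scatter) in this assay, so a change here can move this read-out by a large amount. The size of that step has only a lower bound, and the step between compound 1 and compound 2 cannot be read at all. Compound 1 and compound 2 remain limits of the assay and not numbers: the limit of > 10000000 nM in this assay, at which 2 of the 3 values shown sit.

Going by these compounds, whether chloro is needed at this position stays open. A methyl group, a methoxy group or an amine in the same place would help to show how particular the change is.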